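The compounds below may be only part of what the source reports. "The series", "measured", "known", "first", "only" and "open" are said of these compounds alone.

Compound 3 `Cc1ccc(S(=O)(=O)N(C)CCCN(C)C)cc1C#Cc1cc(Cl)ccc1OCC(=O)O` carries the shared core of this small set, and in an assay on CHO cells for displacement of a labelled ligand from prostaglandin D2 receptor 2 (Homo sapiens), read by scintillation counting (on this read-out lower numbers stand for stronger inhibition and higher numbers for weaker inhibition), compound 3 gives 287 nM, the highest of the three numbers measured. Compound 1 `COCCN(C)S(=O)(=O)c1ccc(C)c(C#Cc2cc(Cl)ccc2OCC(=O)O)c1` gives 4.1 nM in this assay, and compound 2 `Cc1ccc(S(=O)(=O)N2CCN(C)CC2)cc1C#Cc1cc(Cl)ccc1OCC(=O)O` gives 21 nM. The step from compound 1 to compound 3 brought a 70-fold higher number from compound 1 to compound 3 (1.85 log units; beyond the scatter), and the step from compound 2 to compound 3 brought a 14-fold higher number from compound 2 to compound 3 (1.14 log units; beyond the scatter), so both changes that arrive at compound 3 ran strongly upward. Compound 4 `Cc1ccc(S(=O)(=O)N2CCCCC2C)cc1C#Cc1cc(Cl)ccc1OCC(=O)O` undoes that group: 2-methylpiperidin-1-yl in place of (3-(dimethylamino)propyl)(methyl)amino on a sulfonyl sulfur. The entering ring resembles the 4-methylpiperazin-1-yl of compound 2 more than the open chain of compound 3, so the move from compound 3 to compound 4 is expected to reverse the earlier rise and give a markedly lower number in this assay, roughly a 19-fold lower number from compound 3 to compound 4 (1.28 log units; beyond the scatter). Compound 4 is therefore estimated at 15 nM, with a plausible range from 4 nM to 60 nM, while its actual measurement remains to be seen.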

Compound 4, inhibition constant: 1.9 nM
Beside the measured number, compound 4's estimate is 7.9-fold (0.90 log units) above it; the measured number lies below the stated range.
By their numbers in this assay, from the lowest: compound 4; then compound 1; then compound 2; then compound 3.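

Putting 2-methylpiperidin-1-yl in place of (3-(dimethylamino)propyl)(methyl)amino on the sulfonyl sulfur gives a 150-fold lower number from compound 3 to compound 4 (2.18 log units; beyond the scatter) in this assay, a wider swing than any earlier step at this position. Having a ring is not enough to set the number, since 2-methylpiperidin-1-yl in place of 4-methylpiperazin-1-yl still gives an 11-fold lower number from compound 2 to compound 4 (1.04 log units; beyond the scatter) in this comparison. Nor is a ring needed for a low number, as the open (2-methoxyethyl)(methyl)amino group trails by only a modest margin, with a 2.2-fold lower number from compound 1 to compound 4 (0.33 log units; beyond the scatter), leaving compound 4 the lowest of the four.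

Still open, going by these compounds, is how much of this depends on the methyl group of the ring, a question that plain piperidin-1-yl would help answer. The compounds shown also offer no evidence on why these numbers differ.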